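The compounds below may be only part of what the source reports. "The series", "measured", "known", "first", "only" and "open" are said of these compounds alone.

Measured compounds:
- Compound 2 `CCC(C)C(NC(=O)NO)C(=O)NC1CCCCC1`: 153000 nM
- Compound 1 `CC(C)C(NC(=O)NO)C(=O)NC1CCCCC1`: > 100000 nM (a limit)
- Compound 3 `CC(C)C1NC(=O)N(C2CCCCC2)C1=O`: > 200000 nM (a limit)

Within the data shown here, in a functional assay on CCRF-CEM cells (Homo sapiens) for inhibition (on this read-out lower numbers stand for stronger inhibition and higher numbers for weaker inhibition), compound 2 gives 153000 nM, the only plain number among the three measured compounds. Compound 1 reaches only > 100000 nM, which is a limit of the assay and not a number. Compound 3 likewise reaches only > 200000 nM, again a limit. The step from compound 1 to compound 2, a step that the limit leaves unreadable from compound 1 to compound 2, cannot be sized because the limit of > 100000 nM in this assay, at which 1 of the 3 values shown sits, hides where compound 1 truly stands. Compound 3 carries a different core, so its value and that of compound 2 can only be set side by side without a step between them.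

Compound 4 `CCC(C)C(NC(=O)NO)C(=O)NC1CCCC1` differs from compound 2 by cyclopentyl in place of cyclohexyl on an amide-type nitrogen. Among the measured compounds shown here, none of the measured steps touches the ring on the amide nitrogen, so no measured step bears on this change, and the expected step of a 1.0-fold lower number from compound 2 to compound 4 (0.01 log units; within the scatter) is none beyond the scatter. Compound 4 is therefore estimated at 150000 nM, with a range from 50000 nM to 450000 nM.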

Compound 4, half-maximal inhibitory concentration: > 100000 nM
Compound 4 was reported as a limit; the forecaster's own chance of this, stated with the estimate: 40%; the middle value does not contradict the limit.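

Compound 4 comes back as a limit and not a number, so the step from compound 2 to compound 4 cannot be sized: the limit of > 100000 nM in this assay, at which 2 of the 4 values shown sit.

The compounds shown leave open where compound 4 truly stands in this assay, and so whether cyclopentyl in place of cyclohexyl on an amide-type nitrogen changes the read-out at all.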